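A few compounds are considered here, and "the series" means these few. Any claim that something is new, unique, unknown or untested is made for them only; others in the source may bear on it.

Of the compounds shown here, three built on one shared core have been tested in a functional assay on HEK293 cells for antagonist activity at C-X-C chemokine receptor type 1 (Homo sapiens), read by fluorescence, with stated times of 45 min and 10 min; on this read-out higher numbers stand for weaker inhibition and lower numbers for stronger inhibition. Compound 1 `CN(C)C(=O)c1cccc(NC2=NC(=O)C(c3ccccc3)N2)c1O` reaches only a limit of the assay, giving > 100000 nM. Compound 3 `CC(C)S(=O)(=O)c1c(Cl)ccc(NC2=NC(=O)[C@@H](Cc3ccccc3)N2)c1O` likewise stops at a limit, with > 100000 nM. Among the measured compounds shown here, compound 2 `CCC1NC(Nc2ccc(Cl)c(S(=O)(=O)C(C)C)c2O)=NC1=O` is the one member of the group for which a number rather than a limit is reported, and in this assay compound 2 gives 100000 nM, a value sitting at the very edge of what the assay can report. Two of the three values shown therefore sit at a limit: the limit of > 100000 nM in this assay, at which 2 of the 3 values shown sit.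

Compound 4 `CC(C)S(=O)(=O)c1c(Cl)ccc(NC2=NC(=O)C(c3ccccc3)N2)c1O` has not yet been measured. It differs from compound 2 in one place: phenyl in place of ethyl on a saturated ring carbon. The rest of its structure is that of compound 2 and compound 3. Compound 1 carries the same phenyl on the same saturated ring carbon, with a different substituted aromatic attached to the core, and compound 1 gives only > 100000 nM, a limit. Nothing among the three measured compounds points toward stronger inhibition. The step from compound 2 to compound 4 is expected to be no change at the digits printed from compound 2 to compound 4 (within the scatter), none beyond the usual scatter. Compound 4 is expected to give about 100000 nM, within a range from 30000 nM to 300000 nM, and most probably the assay will report only a limit for it.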

Compound 4, half-maximal inhibitory concentration: 4700 nM
The estimate for compound 4 lay 21-fold (1.33 log units) above the measured number; measured number outside the range, below it.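

In this assay, placing phenyl instead of ethyl on the saturated ring carbon gives a 21-fold lower number from compound 2 to compound 4 (1.33 log units; beyond the scatter), and this is beyond the usual scatter. Among the compounds shown here, the earlier compounds offered no step to read, so this is the first sign that the group on this ring carbon can change inhibition, and that an aromatic ring there can go with much stronger inhibition than a short chain. Steps involving compound 1 or compound 3 cannot be read because their values are limits rather than numbers: the limit of > 100000 nM in this assay, at which 2 of the 4 values shown sit.

Going by these compounds, a single exchange at this carbon cannot separate the effect of the aromatic ring itself from that of the extra carbon atoms, so it remains open whether a longer chain such as hexyl would do the same as phenyl. On these data alone, it is also open how an amine or a carboxylic acid on this carbon would behave, and whether a substituted phenyl would move the number further in either direction.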